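A few compounds are considered here, and "the series" means these few. Any claim that something is new, unique, unknown or untested is made for them only; others in the source may bear on it.

For the measured compounds named here, compound 2 `C#CCN(CCCCOc1ccc2ccc(=O)oc2c1)Cc1ccc(C(C)C)cc1` gives 35400 nM in an ADME assay on isolated protein for inhibition of Amine oxidase [flavin-containing] A (Homo sapiens), read by fluorescence and Amplex Red, with stated times of 15 min and 20 min (on this read-out higher numbers stand for weaker inhibition and lower numbers for stronger inhibition), and stands at one end of the two numbers measured, while compound 1 `C#CCN(CCCCOc1ccc2ccc(=O)oc2c1)Cc1cccc(F)c1` gives 69200 nM and the only measured step, a 2.0-fold lower number from compound 1 to compound 2 (0.29 log units; within the scatter), lies within the scatter. Compound 3 `C#CCN(CCCCOc1ccc2ccc(=O)oc2c1)Cc1ccccc1` differs from compound 2 by hydrogen in place of isopropyl on an aromatic carbon. Going by the values given here, that earlier exchange of the group on the ring is the sole step that bears on this change, and it moved nothing beyond the scatter in this assay. Compound 3 is therefore expected at about 50000 nM, between 20000 nM and 130000 nM. The expected step is a 1.4-fold higher number from compound 2 to compound 3 (0.15 log units; within the scatter), because a 2.0-fold lower number from compound 1 to compound 2 (0.29 log units; within the scatter) showed no movement beyond the scatter.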

Compound 3, half-maximal inhibitory concentration: 89400 nM
For compound 3 the middle estimate is 1.8-fold (0.25 log units) below the measured one; measured number inside the range.
By their numbers in this assay, from the lowest: compounds 2, 1 and 3 (each within the scatter of the next, the first and the last beyond it).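

In this assay, for the compounds shown here, hydrogen in place of isopropyl on the aromatic carbon gives the first step beyond the scatter, though a modest one: a 2.5-fold higher number from compound 2 to compound 3 (0.40 log units; beyond the scatter). Hydrogen in place of fluoro gives a 1.3-fold higher number from compound 1 to compound 3 (0.11 log units; within the scatter), which stays within the scatter, so only the exchange at the isopropyl site registers beyond it. No measurement given here accounts for the step. The compounds shown leave open whether a methyl group, an amine or a carboxylic acid in the place of the isopropyl would read nearer compound 2 or compound 3.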